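Bromo in place of hydrogen on the phenyl of compound 2

This account rests on a few compounds, and the source may have more. Where it says the series, first, only, none or still open, it means among the compounds named here.

Compound 2 `N=C(NCCCc1c[nH]cn1)NCCC(c1ccccc1)c1ccccn1` is the reference point of this comparison. In a functional assay on cardiac atrium for agonist activity at histamine H2 receptor (Cavia porcellus) (a lower number here means a smaller maximal response, a higher number a larger maximal response), compound 2 gives 1. Compound 3 `Cc1ccc(C(CC/N=C(\N)NCCCc2c[nH]cn2)c2ccccn2)cc1` gives 1 in this assay, level with compound 2 at the digits recorded. Compound 1 `N=C(NCCCc1c[nH]cn1)NCCCC(c1ccc(F)cc1)c1ccccn1` gives 0.9, a number that also lies within the usual scatter of compound 2, so the three values do not separate.

Compound 4 `N=C(NCCCc1c[nH]cn1)NCCC(c1ccc(Br)cc1)c1ccccn1` differs from compound 2 by bromo in place of hydrogen on an aromatic carbon. Among the measured compounds shown here, no pair of measured compounds isolates this change; compounds 1 and 3 carry other groups on the phenyl, and their values sit within the scatter of compound 2. A step no larger than the scatter, if anything slightly downward, is expected: a number 0.050 lower from compound 2 to compound 4 (within the scatter). Compound 4 is estimated at 0.95, with a range from 0.8 to 1.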

Compound 4, intrinsic activity: the largest response reached, as a fraction of the reference agonist's: 1
Estimate against measurement, compound 4: 0.050 below; the measured number falls inside the stated range.
By their numbers in this assay, from the lowest: compounds 1, 2, 3 and 4 (each within the scatter of the next).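

Among the compounds shown here, the change from phenyl to 4-bromophenyl gives no change at the digits printed from compound 2 to compound 4 (within the scatter) in this assay, the first step that isolates one change on this ring. Bromo on this aromatic carbon, para to a large group, therefore leaves the maximal response indistinguishable from that of the unsubstituted phenyl. No available evidence bears on the reason for this result.

Open, as far as these compounds go, is whether an amine or a carboxylic acid in the same place would also hold the response in this assay. Also open, from the compounds shown here alone, is whether this result carries over to other aromatic carbons of the ring.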